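An Ethoxycarbonyl for a Phenyl at the Assay Limit

The compounds below may be only part of what the source reports. "The series", "measured", "known", "first", "only" and "open" are said of these compounds alone.

Measured so far:
- Compound 1 `CCOC(=O)Cn1cc(CNC(=O)c2cn(Cc3ccccc3)nn2)nn1`: 35000 nM
- Compound 2 `CCOC(=O)Cn1cc(CNC(=O)c2cn(CC(=O)OCc3ccccc3)nn2)nn1`: > 100000 nM (a limit)
- Compound 3 `CC(=O)OCCn1cc(C(=O)NCc2cn(Cc3ccccc3)nn2)nn1`: > 100000 nM (a limit)

All three compounds were tested in a functional assay on B16 cells (Mus musculus) for cytotoxicity, read by MTT assay, with a stated time of 48 h; on this read-out higher numbers stand for weaker inhibition and lower numbers for stronger inhibition. Compound 3 gives > 100000 nM, which is a limit and not a number. Its exact standing is therefore unknown, and the series is crowded against (the limit of > 100000 nM in this assay, at which 2 of the 3 values shown sit).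

The next compound is compound 4 `CCOC(=O)Cn1cc(CNC(=O)c2cn(CCOC(C)=O)nn2)nn1`, which carries ethoxycarbonyl in place of phenyl on a saturated chain carbon bound to an aromatic nitrogen. Among the measured compounds shown here, one measured step bears on this change. There, benzyloxycarbonyl took the place of phenyl on the same kind of carbon, and the result was an at least 2.8-fold higher number from compound 1 to compound 2 (0.45 log units; beyond the scatter). This single pair points towards weaker inhibition rather than stronger. In this assay, the expected step is a step that the limit leaves unreadable from compound 3 to compound 4. Compound 4 is estimated at 120000 nM, with an expected range of 40000 nM to 300000 nM, and it will most likely be reported only as a limit.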

Compound 4, half-maximal inhibitory concentration: > 100000 nM
Compound 4: only a limit was reported (the forecaster's own chance of this, stated with the estimate: 80%); the middle value lies beyond the limit too.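

In this assay, acetoxymethyl in place of phenyl on a saturated chain carbon bound to an aromatic nitrogen gives an at least 2.8-fold higher number from compound 1 to compound 4 (0.45 log units; beyond the scatter), so a replacement with no ring behaves here like benzyloxycarbonyl, which still holds one. Compound 4 gives > 100000 nM, which is a limit and not a number. The steps to compound 4 from compound 2 and from compound 3 cannot be read, because both ends of each are limits: the limit of > 100000 nM in this assay, at which 3 of the 4 values shown sit.

Only compound 1 gives a true number among these four, so how far each replacement lowers inhibition stays unknown. As far as these compounds go, whether an amine or a carboxylic acid on that saturated chain carbon would bring a value back inside the range of the assay also stays open.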